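Taking the Bromo Off a Barely Cytotoxic Compound

A few compounds are considered here, and "the series" means these few. Any claim that something is new, unique, unknown or untested is made for them only; others in the source may bear on it.

In a functional assay on A549 cells (Homo sapiens) for cytotoxicity (a higher number here means a weaker inhibitor, a lower number a stronger inhibitor), compound 1 `Cc1ccc(S(=O)(=O)N2CC(c3ccc(Br)cc3)NC2=O)cc1` gives > 253000 nM. That is a limit of the assay and not a number. Compound 2 `Cc1ccc(S(=O)(=O)N2C(=O)NCC2c2ccccc2)cc1`, which carries no bromo, gives > 316000 nM, and this too is a limit. Among the measured compounds shown here, compound 3 `O=C1NC(c2ccc(Br)cc2)CN1S(=O)(=O)c1ccc(Cl)cc1` gives 161000 nM, the only true number so far.

Compound 4 `Cc1ccc(S(=O)(=O)N2CC(c3ccccc3)NC2=O)cc1` differs from compound 1 by one change, hydrogen in place of bromo on an aromatic carbon.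

For the measured compounds named here, only one step has been measured, an at least 1.5-fold lower number from compound 1 to compound 3 (0.19 log units; that floor lies within the scatter). It is a different change, chloro in place of methyl on an aromatic carbon, and its floor lies within the scatter, so it says little about losing the bromo. Compound 2 at > 316000 nM is the nearest guide, and it shows that a compound without bromo can also stay at a limit. No step beyond the scatter is therefore expected in this assay. The expected step that the limit leaves unreadable from compound 1 to compound 4 is small, and the assay may again report only a limit. For compound 4 the estimated value is 316000 nM, within an expected range of 160000 nM to 550000 nM.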

Compound 4, half-maximal inhibitory concentration: 12500 nM
The estimate for compound 4 lay 25-fold (1.40 log units) above the measured number, outside the stated range (below it).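

Among the compounds shown here, replacing 4-bromophenyl with phenyl gives an at least 20-fold lower number from compound 1 to compound 4 (1.30 log units; beyond the scatter) in this assay, so this single position, para to a large group, has a clear effect on the read-out, which the earlier compounds could not show. Losing one bromine atom, with the rest of the structure unchanged, takes a compound that yields no true number to one that does, and to a stronger one. Compound 1 gives only a limit, so this step is a floor and its full size cannot be read, because the starting value is not a number: the limit of > 253000 nM in this assay, at which 1 of the 4 values shown sits.

Compound 2, which also carries no bromo, gives > 316000 nM, a limit, so having no bromo is not enough on its own for a readable number. The compounds shown also leave open how this position would respond to other groups, such as an amine, a methoxy group or a carboxylic acid.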